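Removing the methyl from a thiourea pair that shows no cytotoxicity

A few compounds are considered here, and "the series" means these few. Any claim that something is new, unique, unknown or untested is made for them only; others in the source may bear on it.

Measured compounds:
compound 1, `S=C(Nc1ccccc1)Nc1nc2c(Cl)cccc2s1`, > 50000 nM
compound 2, `Cc1ccc2nc(NC(=S)Nc3ccccc3)sc2c1`, > 50000 nM

Both measured compounds share a thiourea that links a phenyl group to a fused bicyclic core, and they differ only in the group on that core. In a functional assay on U-937 cells (Homo sapiens) for cytotoxicity, read by MTT assay, with a stated time of 48 h (a lower number here means a stronger inhibitor, a higher number a weaker inhibitor), compound 1 gives > 50000 nM, which is a limit of the assay and not a number. In this assay compound 2 gives > 50000 nM, again a limit rather than a number. Compound 2 therefore stands at the edge of what the assay can report, and it shares that position with compound 1 (the limit of > 50000 nM in this assay, at which 2 of the 2 values shown sit). For the measured compounds named here, no step between measured compounds can be sized.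

Compound 3, `S=C(Nc1ccccc1)Nc1nc2ccccc2s1`, is not yet measured. It differs from compound 2 by hydrogen in place of methyl on an aromatic carbon. With both neighbours sitting at the limit, no shift beyond the scatter is expected from compound 2 to compound 3, only a step that the limit leaves unreadable from compound 2 to compound 3, and the most likely outcome is another limit. In this assay compound 3 is expected to give about 70000 nM, within a range from 20000 nM to 250000 nM.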

Compound 3, half-maximal inhibitory concentration: > 50000 nM
Compound 3: only a limit was reported; the forecaster's own chance of this, stated with the estimate: 80%; the middle value is on the limit's open side.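

Replacing the methyl of compound 2 or the chloro of compound 1 with the hydrogen of compound 3 gives no step that can be read, because all three results are limits and not numbers: the limit of > 50000 nM in this assay, at which 3 of the 3 values shown sit.

The compounds shown leave open how far each lies beyond that limit, and whether any change to this thiourea series would give a number in this assay.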